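A few compounds are considered here, and "the series" means these few. Any claim that something is new, unique, unknown or untested is made for them only; others in the source may bear on it.

Within the data shown here, in an assay on CHO cells for displacement of a labelled ligand from adenosine receptor A3 (Homo sapiens), read by scintillation counting, with a stated time of 120 min, tested at 1 uM (on this read-out higher numbers stand for more inhibition at the one concentration tested (going by the name of the read-out) and lower numbers for less inhibition), compound 2 `N#Cc1c(N)nc(SCc2cnc[nH]2)c(C#N)c1-c1ccc(OCC2CC2)cc1` gives 1%, the lowest of the two numbers measured so far. Its nearest neighbour is compound 1 `COC(=O)c1cccc(CSc2nc(N)c(C#N)c(-c3ccc(OCC4CC4)cc3)c2C#N)c1`, which in this assay gives 4%; the step of a number 3 percentage points lower from compound 1 to compound 2 (within the scatter) is within the scatter, so the two compounds cannot be ordered on these data. Compound 3 `N#Cc1c(N)nc(SCn2cncn2)c(C#N)c1-c1ccc(OCC2CC2)cc1` has not yet been measured. It differs from compound 2 by 1H-1,2,4-triazol-1-yl in place of 1H-imidazol-5-yl on a saturated chain carbon bound to a sulfur. Among the measured compounds shown here, the only measured step that bears on this change is the one at the same place, from compound 1 to compound 2, and it stayed within the scatter even though the group was exchanged wholesale. On that basis the step of a number 1 percentage points higher from compound 2 to compound 3 (within the scatter) is expected to be no larger than the scatter, in no particular direction. Compound 3 is therefore estimated to give 2% in this assay, with a range from -6% to 10%.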

Compound 3, a percentage reported as inhibition, at one concentration (the size of the read-out at that concentration, not a potency): 1%
Compound 3: the middle estimate sits 1 percentage points above what was measured; low and high end bracket the measured number.
By their numbers in this assay, from the lowest: compounds 2, 3 and 1 (each within the scatter of the next).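

In this assay, the exchange on a saturated chain carbon bound to a sulfur gives no change at the digits printed from compound 2 to compound 3 (within the scatter) even though the ring goes from 1 hydrogen-bond donor and 1 hydrogen-bond acceptor to 0 hydrogen-bond donors and 3 hydrogen-bond acceptors, so this change in counts leaves no readable mark on the number. The step of a number 3 percentage points lower from compound 1 to compound 3 (within the scatter) adds a third group at this place, and the three compounds still cannot be ordered. Nothing at hand gives a reason for these numbers.

As far as these compounds go, whether a group of another kind at this place, such as a primary amine, a carboxylic acid or a longer alkyl chain, would raise the inhibition stays open. So does whether any change on the shared core would move the number at all.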